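The source may report more compounds than this note shows. Statements on the series, on what has been measured and on what is new or still open speak of the compounds shown alone.

Compound 1 `COc1cc(/C=C/C(=O)C2=C(/C=C/c3ccc(O)c(OC)c3)NC(=S)NC2c2ccccc2O)ccc1O` gives 34% in a functional assay, with a stated time of 20 min, tested at 2 uM; a lower number here means a weaker effect, a higher number a stronger effect of the compound at the concentration tested. Among the compounds with values here, compound 2 `COc1cc(/C=C/C(=O)C2=C(/C=C/c3ccc(O)c(OC)c3)NC(=S)NC2c2c(Cl)cccc2Cl)ccc1O` gives 15%, the lowest of the two numbers measured; its only neighbour is compound 1, reached by a number 19 percentage points lower from compound 1 to compound 2 (beyond the scatter). Compound 3 `COc1cc(/C=C/C(=O)C2=C(/C=C/c3ccc(O)c(OC)c3)NC(=S)NC2c2ccccc2Cl)ccc1O` differs from compound 2 by hydrogen in place of chloro on an aromatic carbon. Within the data shown here, no measured step removes a single chloro, so the only guide is the step from compound 1 to compound 2, which replaced the whole group. Since compound 3 keeps one chloro, the expected change a number 7 percentage points higher from compound 2 to compound 3 (within the scatter) is a modest rise, possibly within the scatter. Compound 3 is therefore estimated at 22%, ranging from 8% to 38%.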

Compound 3, a percentage reported as activity, at one concentration (the size of the read-out at that concentration, not a potency): 15.5%
Compound 3: the middle estimate sits 6.5 percentage points above what was measured; measured number inside the range.
By their numbers in this assay, from the lowest: compounds 2 and 3 (each within the scatter of the next); then compound 1.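

In this assay, taking one chloro off the 2,6-dichlorophenyl group to leave 2-chlorophenyl gives no difference that stands out from the scatter, with a number 0.5 percentage points higher from compound 2 to compound 3 (within the scatter). A single chloro in place of the hydroxy is therefore already enough for a step beyond the scatter, with a number 18.5 percentage points lower from compound 1 to compound 3 (beyond the scatter). No evidence at hand gives a reason for this.

As far as these compounds go, whether the hydroxy raises the number or the chloro lowers it stays open. So does what an amine or a fluoro in that place would give.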